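This account rests on a few compounds, and the source may have more. Where it says the series, first, only, none or still open, it means among the compounds named here.

The measured compounds, with their numbers in a functional assay on RKO cells (Homo sapiens) for cytotoxicity, read by MTT assay, with a stated time of 48 h; on this read-out lower numbers stand for stronger inhibition and higher numbers for weaker inhibition:

Compound 1, `CCCCCCOc1ccc2c(Cl)ccnc2c1`, gives 2720 nM.
Compound 2, `Clc1ccnc2cc(OCc3ccccc3)ccc12`, gives 2410 nM.
Compound 3, `CCOc1ccc2c(Cl)ccnc2c1`, gives 3870 nM.

All three share the same core and differ only in the group carried on the oxygen attached to the aromatic ring. Compound 3, with the shortest of these groups, gives the highest of the three numbers, but the distances are small: a 1.4-fold higher number from compound 1 to compound 3 (0.15 log units; within the scatter) and a 1.6-fold higher number from compound 2 to compound 3 (0.21 log units; within the scatter), each of which the scatter of repeated measurements could account for. Likewise a 1.1-fold lower number from compound 1 to compound 2 (0.05 log units; within the scatter) is no real difference.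

Compound 4, `C=CCOc1ccc2c(Cl)ccnc2c1`, is not yet measured. It departs from compound 3 by vinyl in place of methyl on a saturated chain carbon bound to an oxygen on an aromatic ring. For the measured compounds named here, none of the measured steps is the same change, but all three bear on it, since each swaps one group on that oxygen for another, and none of them moved this assay beyond the scatter. The nearest comparison is the step from compound 3 to the longer chain of compound 1, which read a 1.4-fold higher number from compound 1 to compound 3 (0.15 log units; within the scatter) in the reverse direction. On that basis compound 4 is expected to give a number close to that of compound 3, with at most a modest drop: a 1.3-fold lower number from compound 3 to compound 4 (0.11 log units; within the scatter). The estimate for compound 4 is 3000 nM, expected to fall between 1500 nM and 6000 nM.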

Compound 4, half-maximal inhibitory concentration: 2460 nM
The estimate for compound 4 lay 1.2-fold (0.09 log units) above the measured number; the range from low to high includes it.
By their numbers in this assay, from the lowest: compounds 2, 4, 1 and 3 (each within the scatter of the next).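

Compound 4 brings a double bond outside aromatic rings onto the chain bound to the oxygen, and in this assay this change stays within the scatter (a 1.6-fold lower number from compound 3 to compound 4 (0.20 log units; within the scatter)). Putting vinyl in place of phenyl (a 1.0-fold higher number from compound 2 to compound 4 (0.01 log units; within the scatter)) or in place of pentyl (a 1.1-fold lower number from compound 1 to compound 4 (0.04 log units; within the scatter)) also stays within the scatter, so the four groups shown on this oxygen, whether saturated chains, a chain with a double bond or a group carrying a ring, cannot be told apart in this assay. Nothing measured here offers a reason for this flat reading.

All the groups shown on this oxygen are built from carbon and hydrogen alone, so it remains open whether a chain ending in an amine or a carboxylic acid would read the same way. All four compounds also keep the chlorine on the shared core, which leaves open what an amine or a methoxy group in its place would do to the number in this assay.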